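Hydrazone Side-Group Swaps on a Naphthyloxymethyl Oxadiazole Urea

This account rests on a few compounds, and the source may have more. Where it says the series, first, only, none or still open, it means among the compounds named here.

Compound 1 `C/C(=N/NC(=O)Nc1nnc(COc2ccc3ccccc3c2)o1)c1ccc(Cl)cc1`: 300 mg/kg
Compound 2 `COc1ccc(/C=N\NC(=O)Nc2nnc(COc3ccc4ccccc4c3)o2)cc1`: 300 mg/kg

Both measured compounds were tested in a functional assay on the whole organism (strain Swiss albino) with Mus musculus as the target, with a stated time of 4 h; on this read-out lower numbers stand for an effect already at smaller amounts and higher numbers for an effect only at larger amounts of compound. For the measured compounds named here, compound 2 gives 300 mg/kg, and compound 1 gives 300 mg/kg; the two stand level, so compound 2 sits at the same place as its only neighbour. Going by the values given here, the one measured step, no change at the digits printed from compound 1 to compound 2 (within the scatter), shows that exchanging one aromatic side group for another at this position left the read-out unchanged.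

Compound 3 `O=C(N/N=C\c1cccc(O)c1)Nc1nnc(COc2ccc3ccccc3c2)o1` has not yet been measured. It differs from compound 2 in one place: 3-hydroxyphenyl in place of 4-methoxyphenyl on a carbon with a double bond to nitrogen.

Among the compounds with values here, the only step that bears on this change is the one from compound 1 to compound 2, which was no change within the scatter. On that basis no step beyond the scatter is expected in this assay, so the estimated step of no change at the digits printed from compound 2 to compound 3 (within the scatter) is essentially flat. For compound 3 the expected value is 300 mg/kg, with a range from 150 mg/kg to 600 mg/kg.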

Compound 3, minimum effective dose: 300 mg/kg
Compound 3: the middle estimate sits on the measured number at the digits printed; measured number inside the range.
By their numbers in this assay, from the lowest: compounds 1, 2 and 3 (each within the scatter of the next).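

In this assay, the step of no change at the digits printed from compound 2 to compound 3 (within the scatter) shows that the read-out also holds when 3-hydroxyphenyl replaces 4-methoxyphenyl, a change that brings in a hydrogen-bond donor where the leaving group has none. The earlier pair had not tested a donor at this position, and the longer comparison, no change at the digits printed from compound 1 to compound 3 (within the scatter), gives the same flat picture. Nothing measured here accounts for this lack of movement.

From the compounds shown here alone, all three compounds carry a six-membered aromatic ring of carbon at this position, so it remains open whether a dimethylamino group or a carboxylic acid on that ring, or a longer alkyl chain in place of the ring, would shift the dose. Going by these compounds, the core of compound 3 is also held constant throughout, so what changes in that part would do remains unknown.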